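The source may report more compounds than this note shows. Statements on the series, on what has been measured and on what is new or still open speak of the compounds shown alone.

All three measured compounds were tested in a functional assay on PANC-1 cells (Homo sapiens) for cytotoxicity, read by MTT assay, with a stated time of 72 h; on this read-out higher numbers stand for weaker inhibition and lower numbers for stronger inhibition:
compound 1 `CC(=O)c1cccc(NC2=CC(=O)c3ncncc3C2=O)c1` gives 900 nM;
compound 2 `O=C1C(Nc2ccc(Oc3ccccc3)cc2)=CC(=O)c2ncncc21` gives 1800 nM;
compound 3 `O=C1C(Nc2ccc(-c3ccc(F)cc3)cc2)=CC(=O)c2ncncc21` gives 3200 nM.

Compound 3 stands highest of these three numbers. Its nearest neighbour is compound 2, and the gap between them, a 1.8-fold higher number from compound 2 to compound 3 (0.25 log units; within the scatter), lies within the scatter, so the two cannot be ordered. Compound 1 lies furthest from compound 3, far enough to stand beyond the scatter.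

Compound 4 `Nc1ccc(-c2ccc(NC3=CC(=O)c4ncncc4C3=O)cc2)cc1` has not yet been measured in this assay. It differs from compound 3 in one place: amino in place of fluoro on an aromatic carbon. Within the data shown here, no measured step swaps one group for another at this same place. Among the measured compounds shown here, the only step known, a 1.8-fold higher number from compound 2 to compound 3 (0.25 log units; within the scatter), exchanges phenoxy for 4-fluorophenyl and stays within the scatter; it is a different change and gives no direction for the new one. With nothing pointing up or down, the expected step of a 1.1-fold lower number from compound 3 to compound 4 (0.03 log units; within the scatter) is none beyond the scatter, though the uncertainty is wide. Compound 4 is therefore estimated at 3000 nM, within the range 1000 nM to 9000 nM.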

Compound 4, half-maximal inhibitory concentration: 3700 nM
For compound 4 the middle estimate is 1.2-fold (0.09 log units) below the measured one, within the range that was stated.
By their numbers in this assay, from the lowest: compounds 1, 2, 3 and 4 (each within the scatter of the next, the first and the last beyond it).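

Amino in place of fluoro, on an aromatic carbon para to a large group, brings in one hydrogen-bond donor and one hydrogen-bond acceptor, yet this assay shows a 1.2-fold higher number from compound 3 to compound 4 (0.06 log units; within the scatter) and the two compounds cannot be ordered. At this place, then, the exchange of these two small groups leaves no readable mark on the number. Replacing phenoxy with 4-aminophenyl gives a 2.1-fold higher number from compound 2 to compound 4 (0.31 log units; beyond the scatter) and so clears the scatter, if only modestly, while no measurement available here explains either step.

The compounds shown leave open whether a larger group at this same place, such as a carboxylic acid or a morpholine, would move the number beyond the scatter. Also open, on these data alone, is whether the outer ring is needed at all, which a methyl in place of 4-aminophenyl would test.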